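The source may report more compounds than this note shows. Statements on the series, on what has been measured and on what is new or still open speak of the compounds shown alone.

Of the compounds shown here, two built on one shared core have been measured in an assay on CHO cells for binding affinity to transient receptor potential cation channel subfamily V member 1 (Rattus norvegicus); a lower number here means a stronger inhibitor, a higher number a weaker inhibitor. Compound 1 `CC(C)(C)c1ccc(C/N=C(\S)NCc2ccc(NS(C)(=O)=O)c(O)c2)cc1` gives 750 nM, while compound 2 `CC(C)(C)c1ccc(C/N=C(\S)NCc2ccc(NS(C)(=O)=O)cc2F)cc1` gives 215 nM, the lower of the two numbers, and its gap to compound 1 lies beyond the usual scatter. Compound 3 `CC(C)(C)c1ccc(C/N=C(\S)NCc2ccc(NS(C)(=O)=O)cc2Cl)cc1` has not yet been measured. It differs from compound 2 only by chloro in place of fluoro on an aromatic carbon. Going by the values given here, no step of this kind has been measured here, so the expected change is a 1.1-fold lower number from compound 2 to compound 3 (0.03 log units; within the scatter), small and in no sure direction. Compound 3 is therefore estimated at 200 nM, within a range from 70 nM to 600 nM.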

Compound 3, inhibition constant: 144 nM
Beside the measured number, compound 3's estimate is 1.4-fold (0.14 log units) above it, and the stated range covers the measured number.
By their numbers in this assay, from the lowest: compounds 3 and 2 (each within the scatter of the next); then compound 1.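

Putting chloro in place of fluoro on this aromatic carbon, ortho to a large group and meta to a methanesulfonamido group, gives a 1.5-fold lower number from compound 2 to compound 3 (0.17 log units; within the scatter) in this assay for this pair. Going by these compounds alone, at this position, then, the two groups cannot be told apart in this measurement, which no earlier pair could show. Nothing available explains this result.

Open, on these data alone, is how the position responds to a different kind of group, such as a methoxy, an amine or a trifluoromethyl. Also open, as far as these compounds go, is what a plain hydrogen there would give.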